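Quinoxaline propanoic acid ethers: ring swap at the ether

The source may hold more compounds than are shown below. What is called first, only, known or untested is meant among the compounds shown, and "the series" means these compounds.

Measured so far:
- compound 1 `O=C(O)CCc1nc2ccccc2nc1OCCOc1ccccn1`: 110000 nM
- compound 2 `O=C(O)CCc1nc2ccccc2nc1OCc1cccs1`: "not active" (no number reported)

In an assay for displacement of a labelled ligand from protein deacetylase HDAC6 (Homo sapiens), read by fluorescence polarization, with a stated time of 10 min (a higher number here means a weaker inhibitor, a lower number a stronger inhibitor), compound 1 gives 110000 nM. In this assay compound 2 is reported as "not active" (no number reported), so no number stands for it, and its place relative to compound 1 cannot be fixed beyond the note that compound 1 returned a value and compound 2 did not.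

Compound 3 `O=C(O)CCc1nc2ccccc2nc1OCc1ccccn1` is not yet measured. The change from compound 2 to compound 3 is pyridin-2-yl in place of thiophen-2-yl on a saturated chain carbon bound to an oxygen on an aromatic ring. For the measured compounds named here, no measured pair shows this swap, so the size of the step is unknown; the expectation is a small gain at most, with no step beyond the scatter equally possible, and a further report of no activity also likely.

For compound 3 the estimate in this assay is 150000 nM, within 40000 nM to 600000 nM.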

Compound 3, half-maximal inhibitory concentration: 270000 nM
For compound 3 the middle estimate is 1.8-fold (0.26 log units) below the measured one; the measured number falls inside the stated range.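

In this assay, going from ((pyridin-2-yl)oxy)methyl to pyridin-2-yl on a saturated chain carbon bound to an oxygen on an aromatic ring gives a 2.5-fold higher number from compound 1 to compound 3 (0.39 log units; beyond the scatter) and so shows that this place responds to the change, with the longer group of compound 1 holding the lower number. Compound 3 returns a number where compound 2 returned none, so the swap between thiophen-2-yl and pyridin-2-yl separates a value from no value and cannot be read as a step. Nothing available here accounts for either result.

Open, from the compounds shown here alone, is whether a phenyl ring or a longer chain ending in pyridin-2-yl at this place would lower the number. Also open, going by these compounds, is how these ethers read when a hydroxamic acid replaces the carboxylic acid.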